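Swapping an amine tail on a shared amide linker

The source may hold more compounds than are shown below. What is called first, only, known or untested is meant among the compounds shown, and "the series" means these compounds.

Of the compounds shown here, three have been measured in a functional assay on A549 cells (Homo sapiens) for antiproliferative activity, read by MTT assay, with a stated time of 48 h (a lower number here means a stronger inhibitor, a higher number a weaker inhibitor), and a fourth waits. Compound 1 `CCNCC(=O)Nc1cc(OC)ccc1C(=O)c1cc(OC)c(OC)c(OC)c1` gives 750 nM in this assay. Within the data shown here, compound 2 `COc1ccc(C(=O)c2cc(OC)c(OC)c(OC)c2)c(NC(=O)CN(C)C)c1` carries dimethylamino in place of ethylamino on a saturated chain carbon bound to a carbonyl carbon and gives 590 nM; the step of a 1.3-fold lower number from compound 1 to compound 2 (0.10 log units; within the scatter) is the only counted change among the measured compounds. Compound 3 `C=C(c1ccc(OC)cc1NC(=O)CNCC)c1ccc(OC)c2c1OC(C)(C)C=C2` is built on a different core, and the difference between the two cores is not broken down here; in this assay compound 3 gives 970 nM, which sits within the scatter of the numbers for compound 1 and compound 2.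

Compound 4 `C=C(c1ccc(OC)cc1NC(=O)CN(C)C)c1ccc(OC)c2c1OC(C)(C)C=C2` is not yet measured. It differs from compound 3 by dimethylamino in place of ethylamino on a saturated chain carbon bound to a carbonyl carbon, the same change that turns compound 1 into compound 2, with the place described in the same words. What is expected of compound 4 rests only on that one earlier step and on the value of compound 3. Since the step from compound 1 to compound 2 stayed within the scatter, a step of a similar size, a 1.3-fold lower number from compound 3 to compound 4 (0.11 log units; within the scatter), is expected from compound 3 to compound 4, and the number for compound 4 is estimated at 750 nM, with a range from 400 nM to 1500 nM. One earlier step on another core is a thin basis, so the range is kept wide.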

Compound 4, half-maximal inhibitory concentration: 270 nM
The estimate for compound 4 lay 2.8-fold (0.44 log units) above the measured number; the measured number lies below the stated range.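

In this assay, the change from ethylamino to dimethylamino brings a 3.6-fold lower number from compound 3 to compound 4 (0.56 log units; beyond the scatter), and it does not carry over at the same size from one core to the other: the same change on two cores in this assay, a 1.3-fold lower number (0.10 log units; within the scatter) from compound 1 to compound 2 and a 3.6-fold lower number (0.56 log units; beyond the scatter) from compound 3 to compound 4, 2.8-fold (0.45 log units) apart, beyond the scatter of two such steps. This shows that, in this series, the size of the step measured on one core was a poor guide to its size on the other, and that the core carrying the amine tail has to be counted when such a step is read. It does not show why the two cores differ, and with one pair on each core it gives no rule for other amine tails or other cores; because the step on the core of compound 1 stays within the scatter, as the comparison of the two steps sets out, it also cannot be said that this change moves the number the same way on both cores: the same change on two cores in this assay, a 1.3-fold lower number (0.10 log units; within the scatter) from compound 1 to compound 2 and a 3.6-fold lower number (0.56 log units; beyond the scatter) from compound 3 to compound 4, 2.8-fold (0.45 log units) apart, beyond the scatter of two such steps.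

The compounds shown leave open how a diethylamino group or a plain primary amine would behave on a saturated chain carbon bound to a carbonyl carbon. They also leave open whether a longer chain carrying the amine would show the same gap between the two cores.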